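Anilide ring substituent swap in the piperidine acetamide series

This account rests on a few compounds, and the source may have more. Where it says the series, first, only, none or still open, it means among the compounds named here.

Compound 1 `O=C(CN1CCC(c2cccc[n+]2[O-])CC1)Nc1cccc(Cl)c1` gives 76% in a functional assay on HEK293 cells for agonist activity at D(4) dopamine receptor (Homo sapiens), read by FLIPR (on this read-out higher numbers stand for larger maximal responses and lower numbers for smaller maximal responses), the highest of the three numbers shown, though compound 2 `Cc1cccc(NC(=O)CN2CCC(c3ccccc3C#N)CC2)c1` with 71% lies within the scatter of it. Compound 3 `Cc1cccc(NC(=O)CN2CCC(c3ccc(O)cc3)CC2)c1` gives 60%. Going by the values given here, the only step among the measured compounds, a number 11 percentage points lower from compound 2 to compound 3 (beyond the scatter), concerns the aryl group on the saturated ring and not the anilide end of the molecule. Compound 4 `CCc1cccc(NC(=O)CN2CCC(c3cccc[n+]3[O-])CC2)c1` differs from compound 1 only at the anilide: ethyl in place of chloro on an aromatic carbon. Among the compounds with values here, no measured step touches this position, so nothing beyond the scatter is expected from the exchange. The step is expected to be a number 4 percentage points lower from compound 1 to compound 4 (within the scatter). Compound 4 is therefore estimated at 72%, with a range from 60% to 84%.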

Compound 4, largest response reached (reported as efficacy), in percent of the reference or control that the assay uses: 62%
Beside the measured number, compound 4's estimate is 10 percentage points above it; the range from low to high includes it.
By their numbers in this assay, from the lowest: compounds 3, 4, 2 and 1 (each within the scatter of the next, the first and the last beyond it).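

At this position in this assay, ethyl in place of chloro gives a number 14 percentage points lower from compound 1 to compound 4 (beyond the scatter). Going by these compounds alone, this is the first readable step at the anilide end, and it shows that the response is sensitive to this exchange on the aromatic carbon, though only modestly. Nothing available explains the step.

On these data alone, it remains open whether a step of this size would recur with the 2-cyanophenyl or 4-hydroxyphenyl group in place of the group on the saturated ring of compound 1. As far as these compounds go, the response with methoxy or an amine at this position also remains open.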